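The source may report more compounds than this note shows. Statements on the series, on what has been measured and on what is new or still open speak of the compounds shown alone.

Working notes on the series.

Of the compounds shown here, three share the core and have been measured. Compound 1 `COc1cccc(-c2cnc(N)nc2-c2ccccc2)c1` is reported in an assay on CHO cells for displacement of a labelled ligand from adenosine receptor A1 (Homo sapiens), read by scintillation counting, with a stated time of 1 h, tested at 1 uM (on this read-out higher numbers stand for more inhibition at the one concentration tested (going by the name of the read-out) and lower numbers for less inhibition), as > 80%, which is a limit of the assay rather than a number (the limit of > 80% in this assay, at which 1 of the 3 values shown sits). Compound 2 `COc1cc(-c2cnc(N)nc2-c2ccccc2)cc(OC)c1OC` gives 56% in this assay. Compound 3 `O=C(Nc1ncc(-c2cccc(Cl)c2)c(-c2ccccc2)n1)C1CCC1` gives 52% in this assay; compound 3 therefore stands lowest of the two numbers shown, with compound 2 nearest at a gap that lies within the scatter. Within the data shown here, no step between measured compounds that differ in one place is available.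

Compound 4 `Clc1cccc(-c2cnc(NC3CCCCC3)nc2-c2ccccc2)c1` is not yet measured. It differs from compound 3 as follows: cyclohexyl in place of cyclobutylcarbonyl on a nitrogen on an aromatic ring. Among the measured compounds shown here, no measured pair in this set changes a group on that nitrogen, so the direction of the step is open; a move of moderate size in either direction, or none beyond the scatter, is plausible. Compound 4 is expected to give about 50% in this assay, between 25% and 75%, a step of a number 2 percentage points lower from compound 3 to compound 4 (within the scatter) being the expectation.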

Compound 4, a percentage reported as inhibition, at one concentration (the size of the read-out at that concentration, not a potency): 58%
Compound 4: middle estimate off by 8 percentage points, on the low side; the measured number falls inside the stated range.
By their numbers in this assay, from the lowest: compounds 3, 2 and 4 (each within the scatter of the next). At a limit, above all of these: compound 1.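

Among these compounds, the change of cyclobutylcarbonyl to cyclohexyl on a nitrogen on an aromatic ring gives the first reading at this position: in this assay the step is a number 6 percentage points higher from compound 3 to compound 4 (within the scatter). On this single pair, the carbonyl on that nitrogen can therefore be exchanged for a carbon-only ring without a difference beyond the scatter, although ring size and carbonyl change together and cannot be told apart. Nothing at hand gives a cause for this step.

Open, on these data alone, is what cyclobutyl without the carbonyl, cyclohexylcarbonyl or a longer chain such as hexyl on that nitrogen would give, which would separate the ring from the carbonyl. Also open, as far as these compounds go, is whether this step holds with other groups on the shared core, since it rests on one pair.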